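The source may report more compounds than this note shows. Statements on the series, on what has been measured and on what is new or still open speak of the compounds shown alone.

The measured compounds:
- compound 1 `CCOC(=O)c1nc(C)c2c(c1N)C(=O)N(Cc1ccccc1)C2=O`: in a physicochemical assay for solubility, using the shake flask method, in simulated intestinal fluid, measured as kinetic solubility, with a stated time of 2 h, at 25 degrees C, at pH 6.5 (a lower number here means a less soluble compound, a higher number a more soluble compound), compound 1 gives < 5000 nM, a limit of the assay rather than a number.
- compound 2 `Cc1nc(C#N)c(N)c2c1C(=O)N(Cc1ccccc1)C2=O`: in this assay compound 2 gives < 5000 nM, again a limit of the assay.
- compound 3 `CNC(=O)c1nc(C)c2c(c1N)C(=O)N(Cc1ccccc1)C2=O`: in this assay compound 3 gives 41000 nM.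

Compound 2 therefore stands at the floor of what this assay can report, as described by the limit of < 5000 nM in this assay, at which 2 of the 3 values shown sit, sharing that floor with compound 1. The step to compound 4 `Cc1nc(-c2nc(C(F)(F)F)no2)c(N)c2c1C(=O)N(Cc1ccccc1)C2=O` is 3-(trifluoromethyl)-1,2,4-oxadiazol-5-yl in place of cyano on an aromatic carbon. Of the measured steps, a step that the two limits leave unreadable from compound 1 to compound 2 cannot be read because both ends are limits, and an at least 8.2-fold higher number from compound 2 to compound 3 (0.91 log units; beyond the scatter) concerns a different group, methylcarbamoyl, so neither speaks directly to the trifluoromethyl-oxadiazolyl group. Nothing measured here suggests that compound 4 would rise above the floor, so no readable change is expected, with the step that the limit leaves unreadable from compound 2 to compound 4 expected to stay within the scatter. Compound 4 is estimated at 2000 nM, between 400 nM and 7000 nM, most likely reported again only as a limit.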

Compound 4, solubility: < 5000 nM
Compound 4 was reported as a limit; the forecaster's own chance of this, stated with the estimate: 80%; the middle value is on the limit's open side.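

On the aromatic carbon next to the ring nitrogen, a five-membered aromatic ring with 3 hetero atoms, carrying trifluoromethyl, in place of cyano leaves the compound at the floor of this assay: the limit of < 5000 nM in this assay, at which 3 of the 4 values shown sit. The one readable comparison is an at least 8.2-fold lower number from compound 3 to compound 4 (0.91 log units; beyond the scatter), so methylcarbamoyl stays the only one of the four groups shown at this position that gives a number rather than a limit. The steps to compound 4 from compound 1 and from compound 2 have limits at both ends and cannot be read.

From the compounds shown here alone, how far under the limit compound 1, compound 2 and compound 4 lie stays open, and so does any order among them. Also open, going by these compounds, is whether a primary carboxamide, a dimethylamide, a carboxylic acid or an aminomethyl group at this position would give a number as methylcarbamoyl does.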